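Trifluoromethyl for fluoro on the aryl piperazine

This account rests on a few compounds, and the source may have more. Where it says the series, first, only, none or still open, it means among the compounds named here.

Of the compounds shown here, three sharing one core have been measured in a functional assay on the whole organism (strain Swiss) with Mus musculus as the target, in the maximal electroshock model, with a stated time of 1 h, at a dose of 300 mg/kg by the intraperitoneal route; a lower number here means a weaker effect, a higher number a stronger effect of the compound at the dose given. Compound 1 `CCC(C(=O)N1CCN(c2cccc(Cl)c2)CC1)N1C(=O)CCC1=O` gives 100%. Compound 2 `CCC(C(=O)N1CCN(c2ccccc2F)CC1)N1C(=O)CCC1=O` gives 50%, and compound 3 `CCC(C(=O)N1CCN(c2ccc(Cl)cc2)CC1)N1C(=O)CCC1=O` gives 25%. Compound 2 thus stands second highest of the three: the step of a number 50 percentage points lower from compound 1 to compound 2 (beyond the scatter) sets it below compound 1, while the step of a number 25 percentage points lower from compound 2 to compound 3 (beyond the scatter) sets it above compound 3.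

Compound 4 `CCC(C(=O)N1CCN(c2ccccc2C(F)(F)F)CC1)N1C(=O)CCC1=O` differs from compound 2 by the change (trifluoromethyl in place of fluoro on an aromatic carbon). Among the compounds with values here, no measured step exchanges one group for another at the same place on the aryl ring; the steps of a number 50 percentage points lower from compound 1 to compound 2 (beyond the scatter), a number 75 percentage points lower from compound 1 to compound 3 (beyond the scatter) and a number 25 percentage points lower from compound 2 to compound 3 (beyond the scatter) only show that the nature and place of the aryl substituent move the read-out in this assay by large to modest amounts. The direction for compound 4 is therefore open, and compound 4 is expected to lie near compound 2, with a step of no change at the digits printed from compound 2 to compound 4 (within the scatter) that could fall either way. Compound 4 is estimated at 50% in this assay, between 25% and 75%.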

Compound 4, a percentage reported as activity, at one dose (the size of the read-out at that dose, not a potency): 0%
The estimate for compound 4 lay 50 percentage points above the measured number; measured number outside the range, below it.
By their numbers in this assay, from the lowest: compound 4; then compound 3; then compound 2; then compound 1.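

Within the data shown here, this is the first exchange of one group for another at the same place on the aryl ring, and in this assay it is not neutral: the step is a number 50 percentage points lower from compound 2 to compound 4 (beyond the scatter). At this place, ortho to a large group, replacing fluoro with trifluoromethyl takes compound 4 to 0%, so this position does not tolerate every small halogen-bearing group equally, even though the count of hydrogen-bond donors and acceptors stays the same. No measured information is available to account for the size of this step.

The compounds shown leave open how a methyl or methoxy group would behave at this same place on the ring. They also leave open whether trifluoromethyl at another place on the ring would give a similarly low read-out.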